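Swapping a Methyl for Fluorine on the Outer Ring

The source may hold more compounds than are shown below. What is called first, only, known or untested is meant among the compounds shown, and "the series" means these compounds.

All three measured compounds were tested in an ADME assay on GES1 cells (Homo sapiens) for cytotoxicity, read by MTT assay, with a stated time of 24 h; a lower number here means that less compound is tolerated, a higher number that more compound is tolerated:

compound 1 `O=c1[nH]cc(S(=O)(=O)Nc2ccc(-c3cn(-c4ccccc4)nn3)cc2)c(=O)[nH]1`: "not toxic" (no number reported)
compound 2 `Cc1ccccc1-n1cc(-c2ccc(NS(=O)(=O)c3c[nH]c(=O)[nH]c3=O)cc2)nn1`: "not toxic" (no number reported)
compound 3 `Cc1cccc(-n2cc(-c3ccc(NS(=O)(=O)c4c[nH]c(=O)[nH]c4=O)cc3)nn2)c1`: 28300 nM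

Compound 3 is the only one of the three with a number; compounds 1 and 2 were simply reported as not toxic, so there is nothing to rank compound 3 against, and it is best read as a compound that is tolerated up to a high concentration.

Compound 4 `O=c1[nH]cc(S(=O)(=O)Nc2ccc(-c3cn(-c4ccccc4F)nn3)cc2)c(=O)[nH]1` has not yet been measured in this assay. It differs from compound 3 in one place: 2-fluorophenyl in place of 3-methylphenyl on an aromatic nitrogen. Among the compounds with values here, no pair of measured compounds differs by exactly this change, so the step has to be judged from the whole set. Compounds 1 and 2, which differ from compound 4 only in that outer ring, were not toxic, and compound 3 was tolerated well.

The step is therefore expected to be small, a 1.4-fold higher number from compound 3 to compound 4 (0.15 log units; within the scatter), if anything toward more compound tolerated, and probably not beyond the scatter of repeated measurements. Compound 4 is expected to give about 40000 nM in this assay, within a range from 15000 nM to 120000 nM. There is a fair chance that compound 4 comes back with no number at all.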

Compound 4, half-maximal cytotoxic concentration: > 100000 nM
Compound 4 was reported as a limit; the forecaster's own chance of this, stated with the estimate: 50%; middle value at least 2.5-fold (0.39 log units) from the limit.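

In this assay compound 4 gives > 100000 nM, which is a limit of the assay and not a number. Placing 2-fluorophenyl where compound 3 carries 3-methylphenyl, on the aromatic nitrogen, gives an at least 3.5-fold higher number from compound 3 to compound 4 (0.54 log units; beyond the scatter), so a change confined to this outer ring can move the tolerated concentration by more than repeat measurements would. The earlier compounds could not show this, as compound 3 alone had a number, and the new step is only a minimum, with its true size unknown and its upper end set by the top of the reported range: the limit of > 100000 nM in this assay, at which 1 of the 4 values shown sits.

Steps involving compounds 1 and 2 cannot be read, as neither has a number, so it remains unclear how the unsubstituted phenyl of compound 1 or the methyl-bearing ring of compound 2 compares with the rings of compounds 3 and 4. As far as these compounds go, it also remains open whether an outer ring carrying a chlorine, a methoxy group, an amine or a carboxylic acid would be tolerated as well as the 2-fluorophenyl ring of compound 4 or would fall closer to compound 3.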